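The source may hold more compounds than are shown below. What is called first, only, known or untested is meant among the compounds shown, and "the series" means these compounds.

Measured in a functional assay on MGC-803 cells (Homo sapiens) for inhibition, read by MTT assay, with a stated time of 48 h; a higher number here means a weaker inhibitor, a lower number a stronger inhibitor:
compound 1 `C=C(C)C(=O)N(Cc1ccc(OC)c(O)c1)c1cc(OC)c(OC)c(OC)c1`: 390 nM
compound 2 `CC/C=C/C(=O)N(Cc1ccc(OC)c(O)c1)c1cc(OC)c(OC)c(OC)c1`: 58 nM
compound 3 `C=CC(=O)N(Cc1ccc(OC)c(O)c1)c1cc(OC)c(OC)c(OC)c1`: 62 nM

In this assay compound 3 stands second highest of the three numbers. Its nearest neighbour is compound 2, with a 1.1-fold higher number from compound 2 to compound 3 (0.03 log units; within the scatter); the furthest is compound 1, with a 6.3-fold lower number from compound 1 to compound 3 (0.80 log units; beyond the scatter). Compound 4 `COc1ccc(CN(C(=O)/C=C/CBr)c2cc(OC)c(OC)c(OC)c2)cc1O` differs from compound 3 in one place: 3-bromoprop-1-en-1-yl in place of vinyl on a carbonyl carbon.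

The step that bears on this change sits on the same carbonyl carbon, a 1.1-fold higher number from compound 2 to compound 3 (0.03 log units; within the scatter), and lies within the scatter, so lengthening the chain on that carbon left the number where it was. The other step on that carbon, a 6.7-fold lower number from compound 1 to compound 2 (0.83 log units; beyond the scatter), concerns a different group and is the only one beyond the scatter here. For compound 4 a step of a 1.1-fold lower number from compound 3 to compound 4 (0.05 log units; within the scatter) is therefore expected, not beyond the scatter. Compound 4 is estimated at 55 nM, range 20 nM to 160 nM.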

Compound 4, half-maximal inhibitory concentration: 71 nM
For compound 4 the middle estimate is 1.3-fold (0.11 log units) below the measured one; measured number inside the range.
By their numbers in this assay, from the lowest: compounds 2, 3 and 4 (each within the scatter of the next); then compound 1.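

In this assay, 3-bromoprop-1-en-1-yl in place of vinyl on the carbonyl carbon shows a 1.1-fold higher number from compound 3 to compound 4 (0.06 log units; within the scatter), and bromo in place of methyl on the chain shows a 1.2-fold higher number from compound 2 to compound 4 (0.09 log units; within the scatter), so a bromine-bearing chain at this position sits with the vinyl and but-1-en-1-yl groups. The 1-methylethenyl group of compound 1 remains apart, with a 5.5-fold lower number from compound 1 to compound 4 (0.74 log units; beyond the scatter). No measurement shown gives a reason for these results. As far as these compounds go, whether an amine or a carboxylic acid in place of the bromine, or a longer chain, would hold the number at this level remains open.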